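This account rests on a few compounds, and the source may have more. Where it says the series, first, only, none or still open, it means among the compounds named here.

Measured compounds:
compound 1 `COc1ccc(-n2c(SC(C)C(=O)Nc3ncc(C(F)(F)F)cc3Cl)nc3ccccc32)cc1` — 9200 nM
compound 2 `COc1ccc(-n2c(SC(C)C(=O)Nc3nnc(C)c(C)n3)nc3ccccc32)cc1` — "not determined" (no result reported)
compound 3 `COc1ccc(-n2c(SC(C)C(=O)Nc3nc(C)c(Cl)cc3Cl)nc3ccccc32)cc1` — 7250 nM

In an ADME assay on Vero cells (Chlorocebus sabaeus) for cytotoxicity, read by MTT assay, with a stated time of 24 h (a lower number here means that less compound is tolerated, a higher number that more compound is tolerated), compound 3 gives 7250 nM, the lowest of the two numbers reported; its nearest neighbour is compound 1, and the step of a 1.3-fold lower number from compound 1 to compound 3 (0.10 log units; within the scatter) lies within the scatter. Compound 2 carries no number in this assay, so it offers no comparison.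

Compound 4 `COc1ccc(-n2c(SC(C)C(=O)Nc3ncc(C)cc3Cl)nc3ccccc32)cc1` differs from compound 3 in one place: 3-chloro-5-methylpyridin-2-yl in place of 3,5-dichloro-6-methylpyridin-2-yl on an amide-type nitrogen. For the measured compounds named here, the only measured step that bears on this kind of change is the one from compound 1 to compound 3, which also swaps one substituted pyridinyl group for another on the same amide-type nitrogen, and that step stayed within the scatter. With nothing in the data pointing to a shift in either direction, the expectation for compound 4 in this assay is a step of about a 1.0-fold higher number from compound 3 to compound 4 (0.01 log units; within the scatter), that is, none beyond the scatter. Compound 4 is therefore estimated at 7500 nM, with a range from 3500 nM to 16000 nM.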

Compound 4, half-maximal cytotoxic concentration: 880 nM
The estimate for compound 4 lay 8.5-fold (0.93 log units) above the measured number, and the stated range ends above it.
By their numbers in this assay, from the lowest: compound 4; then compounds 3 and 1 (each within the scatter of the next).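

In this assay the group on the amide-type nitrogen turns out not to be an indifferent place: 3-chloro-5-methylpyridin-2-yl in place of 3,5-dichloro-6-methylpyridin-2-yl gives a step beyond the scatter (an 8.2-fold lower number from compound 3 to compound 4 (0.92 log units; beyond the scatter)), unlike the earlier exchange at this nitrogen. For the compounds shown here, the single change of methyl in place of trifluoromethyl on an aromatic carbon gives the largest step seen so far (a 10-fold lower number from compound 1 to compound 4 (1.02 log units; beyond the scatter)), so one small replacement on this group is enough to lower the tolerated concentration markedly. No measurement at hand accounts for these steps.

Going by these compounds, whether an ethyl group or a carboxylic acid on that aromatic carbon would behave like methyl or like trifluoromethyl stays open. So does the effect of a methoxy group in place of the chlorine of 3-chloro-5-methylpyridin-2-yl.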